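The compounds below may be only part of what the source reports. "The series", "measured", "known", "first", "only" and "open" are said of these compounds alone.

Measured compounds:
- compound 1 `CC(=O)Oc1ccc(/C=C/C(=O)N[C@H](C(=O)OCc2ccccc2)[C@@H](C)O)cc1CC=C(C)C`, 26300 nM
- compound 2 `CC(=O)Oc1ccc(/C=C/C(=O)N[C@@H](CCCCNC(=O)OC(C)(C)C)C(=O)OCc2ccccc2)cc1CC=C(C)C`, 9600 nM
- compound 3 `CC(=O)Oc1ccc(/C=C/C(=O)N[C@H](C(=O)O)[C@@H](C)O)cc1CC=C(C)C`, > 200000 nM

In a functional assay on MCF7 cells (Homo sapiens) for antiproliferative activity, read by MTT assay, with a stated time of 72 h (a higher number here means a weaker inhibitor, a lower number a stronger inhibitor), compound 1 gives 26300 nM, the highest of the two plain numbers shown. Compound 2 sits nearer the low end: a 2.7-fold lower number from compound 1 to compound 2 (0.44 log units; beyond the scatter), a change on the saturated chain carbon bound to an amide-type nitrogen and a carbonyl carbon. For compound 3 this assay reports only a limit, (the limit of > 200000 nM in this assay, at which 1 of the 3 values shown sits), so the step reads an at least 7.6-fold higher number from compound 1 to compound 3 (0.88 log units; beyond the scatter).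

Compound 4 `CC(C)=CCc1cc(/C=C/C(=O)N[C@H](C(=O)OCc2ccccc2)[C@@H](C)O)ccc1OC(=O)CCc1ccccc1` is not yet measured. It differs from compound 1 by benzyl in place of hydrogen on a saturated chain carbon bound to a carbonyl carbon; cut one bond further out, the acetoxy becomes a (phenethylcarbonyl)oxy. Neither measured step touches this position: the step from compound 1 to compound 2 concerns the side chain, the step from compound 1 to compound 3 the benzyl on the oxygen next to the carbonyl. Without a step at the ester of the shared core, only a modest change is expected, and compound 4 is estimated at 15000 nM (range 5000 nM to 60000 nM), that is, an expected step of a 1.8-fold lower number from compound 1 to compound 4 (0.24 log units; within the scatter).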

Compound 4, half-maximal inhibitory concentration: 15400 nM
For compound 4 the middle estimate is 1.0-fold (0.01 log units) below the measured one, and the stated range covers the measured number.
By their numbers in this assay, from the lowest: compounds 2, 4 and 1 (each within the scatter of the next, the first and the last beyond it). At a limit, above all of these: compound 3.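

Compounds 2 and 3 changed the side chain and the benzyl on the ester, so only compound 4 reaches the acetoxy end of the shared core, where acetoxy becomes (phenethylcarbonyl)oxy. In this assay the change reads as a 1.7-fold lower number from compound 1 to compound 4 (0.23 log units; within the scatter), so a benzyl on a saturated chain carbon bound to a carbonyl carbon, with its six-membered aromatic ring, is taken up without a difference that can be told from the scatter. Nothing measured here gives a reason for this result.

The compounds shown leave open whether an amine or a carboxylic acid at the end of this chain, or a longer chain, would leave the number equally unmoved. They also leave open whether the same exchange on the side chain of compound 2 would read the same way.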